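Lengthening the ethoxy chain of compound 2 to butoxy

The source may report more compounds than this note shows. Statements on the series, on what has been measured and on what is new or still open speak of the compounds shown alone.

In an ADME assay on L6 cells (Rattus norvegicus) for cytotoxicity, read by resazurin assay, with a stated time of 72 h (on this read-out higher numbers stand for weaker inhibition and lower numbers for stronger inhibition), compound 1 (`COC(=O)c1ccc(C(=O)NC(=O)c2ccccc2O)cc1`) gives 42 ug/mL and compound 2 (`CCOc1ccc(C(=O)NC(=O)c2ccccc2O)cc1`) gives 17 ug/mL, the lower of the two numbers and so the stronger inhibition. Compound 3 (`CCCCOc1ccc(C(=O)NC(=O)c2ccccc2O)cc1`) carries butoxy where compound 2 carries ethoxy: ethyl in place of hydrogen on a saturated chain carbon, two bonds along the chain from an oxygen on an aromatic ring. That is ethyl in place of hydrogen on a saturated chain carbon, two bonds along the chain from an oxygen on an aromatic ring.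

For the measured compounds named here, only one measured step exists, a 2.5-fold lower number from compound 1 to compound 2 (0.39 log units; beyond the scatter). It is modest and beyond the scatter, but it is ethoxy in place of methoxycarbonyl, so it bears on this change only indirectly. Going by the values given here, no measured step lengthens a chain. A modest move towards a lower number in this assay is therefore expected, with little confidence, and it may stay within the scatter. The expected step is a 1.5-fold lower number from compound 2 to compound 3 (0.19 log units; within the scatter). For compound 3 the estimate is 11 ug/mL, with an expected range of 4 ug/mL to 28 ug/mL.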

Compound 3, half-maximal inhibitory concentration: 13 ug/mL
Beside the measured number, compound 3's estimate is 1.2-fold (0.07 log units) below it; measured number inside the range.
By their numbers in this assay, from the lowest: compounds 3 and 2 (each within the scatter of the next); then compound 1.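

Ethyl in place of hydrogen on this saturated chain carbon, two bonds along the chain from an oxygen on an aromatic ring, gives the series its first chain-lengthening step in this assay: a 1.3-fold lower number from compound 2 to compound 3 (0.12 log units; within the scatter) shows no change that can be told from the scatter. Butoxy therefore keeps the separation from the methoxycarbonyl compound, with a 3.2-fold lower number from compound 1 to compound 3 (0.51 log units; beyond the scatter) standing as a modest step beyond the scatter. The data on hand offer no explanation for either step.

As far as these compounds go, whether a longer chain than butoxy would move the number beyond the scatter remains open. Also open, from the compounds shown here alone, is how a branched chain, or a chain carrying an amine or a carboxylic acid, would read in this assay on the same shared core.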